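This account rests on a few compounds, and the source may have more. Where it says the series, first, only, none or still open, it means among the compounds named here.

In a functional assay on HCT-116 cells (Homo sapiens) for cytotoxicity, read by MTT assay, with a stated time of 72 h (a higher number here means a weaker inhibitor, a lower number a stronger inhibitor), compound 1 (`CN1CCN(CCCCn2c3c(c4ccccc42)C(=O)c2c[n+]([O-])c4ccccc4c2C3=O)CC1`) gives 10 nM, while compound 2 (`CN(C)CCCCn1c2c(c3ccccc31)C(=O)c1c[n+]([O-])c3ccccc3c1C2=O`) gives 450 nM, the higher of the two numbers. Compound 3 (`CN1CCN(CCCCCn2c3c(c4ccccc42)C(=O)c2c[n+]([O-])c4ccccc4c2C3=O)CC1`) differs from compound 2 by (4-methylpiperazin-1-yl)methyl in place of dimethylamino on a saturated chain carbon, four bonds along the chain from an aromatic nitrogen: (4-methylpiperazin-1-yl)methyl in place of dimethylamino, on a saturated chain carbon, four bonds along the chain from an aromatic nitrogen. Among the compounds with values here, only one measured step bears on this change, and it is large: a 45-fold higher number from compound 1 to compound 2 (1.65 log units; beyond the scatter). That step exchanged 4-methylpiperazin-1-yl for dimethylamino, so the piperazine return in compound 3 runs opposite to it, and a large fall in the number is expected. Within the data shown here, no measured pair shows the effect of the longer chain alone, which widens the range. The expected change is an 18-fold lower number from compound 2 to compound 3 (1.26 log units; beyond the scatter). For compound 3, the estimated value is 25 nM, within an expected range of 6 nM to 100 nM.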

Compound 3, half-maximal inhibitory concentration: 1220 nM
Beside the measured number, compound 3's estimate is 49-fold (1.69 log units) below it, outside the stated range (above it).
By their numbers in this assay, from the lowest: compound 1; then compound 2; then compound 3.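

In this assay, (4-methylpiperazin-1-yl)methyl in place of 4-methylpiperazin-1-yl on this saturated chain carbon gives a 120-fold higher number from compound 1 to compound 3 (2.09 log units; beyond the scatter) and so removes nearly all of the advantage seen in compound 1, which shows that the piperazine end group alone does not secure a low number. Set against the dimethylamino group, the same (4-methylpiperazin-1-yl)methyl gives a 2.7-fold higher number from compound 2 to compound 3 (0.43 log units; beyond the scatter) in this series, so the outcome at this place depends on where the piperazine stands along the chain as well as on its presence. Nothing measured here gives a reason for this loss. The compounds shown leave open how dimethylamino would fare on the longer chain, which would separate the chain from the end group. They also leave open whether a shorter chain, or a morpholine or piperidine end group, would keep the low number.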